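This account rests on a few compounds, and the source may have more. Where it says the series, first, only, none or still open, it means among the compounds named here.

Two sulfonate esters with a shared core were tested in a functional assay on MCF7 cells (Homo sapiens) for antiproliferative activity, read by sulforhodamine B assay, with a stated time of 48 h; a lower number here means a stronger inhibitor, a higher number a weaker inhibitor. Compound 1 `O=C(CCCCl)Nc1ccc(S(=O)(=O)Oc2ccccc2I)cc1` gives 6300 nM in this assay. Compound 2 `CCNC(=O)Nc1ccc(S(=O)(=O)Oc2ccccc2C(C)C)cc1` gives 10000 nM in this assay, and the two values lie within the usual scatter of each other, so neither can be set apart. Compound 3 `CCNC(=O)Nc1ccc(S(=O)(=O)Oc2ccccc2I)cc1` carries iodo in place of isopropyl on an aromatic carbon. The iodo group is also borne by compound 1, and in this assay compound 1 gives 6300 nM, and on that basis compound 3 is expected to show a step of a 1.4-fold lower number from compound 2 to compound 3 (0.15 log units; within the scatter), not beyond the scatter. Compound 3 is therefore estimated at 7000 nM, with a range from 3000 nM to 16000 nM.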

Compound 3, half-maximal inhibitory concentration: 1100 nM
Compound 3: the middle estimate sits 6.4-fold (0.80 log units) above what was measured; measured number below the stated range.
By their numbers in this assay, from the lowest: compound 3; then compounds 1 and 2 (each within the scatter of the next).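

In this assay the aromatic carbon ortho to a large group proves sensitive: with the ethylamino side held, iodo in place of isopropyl brings a 9.1-fold lower number from compound 2 to compound 3 (0.96 log units; beyond the scatter). The other side counts as well: with iodo held, ethylamino in place of 3-chloropropyl on the carbonyl carbon brings a 5.7-fold lower number from compound 1 to compound 3 (0.76 log units; beyond the scatter). Compound 1 and compound 2 lie within the scatter of each other and gave no sign of either effect, and only compound 3 carries iodo and ethylamino together. Going by these compounds, whether bromo or methoxy at that carbon would match iodo stays open, as does a longer chain in place of ethylamino. Nothing measured here gives a reason for either step.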